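The source may hold more compounds than are shown below. What is called first, only, known or untested is meant among the compounds shown, and "the series" means these compounds.

Measured compounds in a functional assay on SW-620 cells (Homo sapiens) for antiproliferative activity, read by MTT assay, with a stated time of 24 h; on this read-out lower numbers stand for stronger inhibition and higher numbers for weaker inhibition:
compound 1 `COc1ccc(C(=O)/C=C/c2cccc(F)c2)c2c1C=CC(C)(C)O2` — in this assay compound 1 gives > 10000 nM, which is a limit of the assay rather than a number.
compound 2 `COc1ccc(C(=O)/C=C/c2ccc(Cl)c(Cl)c2)c2c1C=CC(C)(C)O2` — in this assay compound 2 gives 7700 nM.

Compound 2 thus holds the only number shown; the other value is a limit. Within the data shown here, the one measured step, an at least 1.2-fold lower number from compound 1 to compound 2 (0.11 log units; that floor lies within the scatter), rests on that limit of > 10000 nM in this assay, at which 1 of the 2 values shown sits, and its floor lies within the scatter, so it gives no firm direction. Compound 3 `COc1ccccc1/C=C/C(=O)c1ccc(OC)c2c1OC(C)(C)C=C2` carries the change (2-methoxyphenyl in place of 3,4-dichlorophenyl on a double-bonded chain carbon bound to a double-bonded chain carbon). Among the measured compounds shown here, no measured step involves a 2-methoxyphenyl, so no change beyond the scatter is expected in this assay. Compound 3 is therefore estimated at 8000 nM, range 2500 nM to 30000 nM. The expected step is a 1.0-fold higher number from compound 2 to compound 3 (0.02 log units; within the scatter).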

Compound 3, half-maximal inhibitory concentration: > 10000 nM
Compound 3 was reported as a limit; the forecaster's own chance of this, stated with the estimate: 40%; middle value at least 1.2-fold (0.09 log units) away from the limit.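

Compound 3 gives > 10000 nM in this assay, which is a limit of the assay and not a number. Placing 2-methoxyphenyl at this position gives an at least 1.2-fold higher number from compound 2 to compound 3 (0.11 log units; that floor lies within the scatter), so the first ring bearing an oxygen substituent here adds no firm direction to the series. The step between the two limited compounds, compound 1 and compound 3, cannot be read, and the values at this place gather at one limit: the limit of > 10000 nM in this assay, at which 2 of the 3 values shown sit.

Still open is what lies behind the limits. Also open, going by these compounds, is whether a phenyl ring carrying an amine or a carboxylic acid at this place would give a clearly lower number.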